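Swapping a Phenol Hydrogen for Methyl: Expected Cytotoxicity

The source may report more compounds than this note shows. Statements on the series, on what has been measured and on what is new or still open speak of the compounds shown alone.

Compound 2 `O=C(/C=C/c1ccc(OCCCCCCO[N+](=O)[O-])c(O)c1)OCCCCCCO[N+](=O)[O-]` was tested in a functional assay on NCI-H1792 cells (Homo sapiens) for cytotoxicity, read by resazurin assay, with a stated time of 72 h; a lower number here means a stronger inhibitor, a higher number a weaker inhibitor. For compound 2 the result is only a limit of the assay, > 50000 nM, not a number. Compound 1 `COc1cc(/C=C/C(=O)OCCCCCO[N+](=O)[O-])ccc1OCCCCCO[N+](=O)[O-]` also reaches only a limit, > 50000 nM. Compound 3 `COc1cc(/C=C/C(=O)OCc2cccc(OCc3c(-c4ccccc4)no[n+]3[O-])c2)ccc1O` likewise stops at a limit, > 50000 nM. Compound 2 therefore stands where every measured compound stands, because of the limit of > 50000 nM in this assay, at which 3 of the 3 values shown sit. Compound 4 `COc1cc(/C=C/C(=O)OCCCCCCO[N+](=O)[O-])ccc1OCCCCCCO[N+](=O)[O-]` differs from compound 2 by methyl in place of hydrogen on an oxygen on an aromatic ring. For the measured compounds named here, no step between two measured compounds is available, so any expectation for this assay can rest only on the three limits. Compound 4 is expected to show a step that the limit leaves unreadable from compound 2 to compound 4, no step beyond the usual scatter. Compound 4 is estimated at 60000 nM, between 20000 nM and 200000 nM.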

Compound 4, half-maximal inhibitory concentration: > 50000 nM
Compound 4 was reported as a limit (the forecaster's own chance of this, stated with the estimate: 85%); the middle value is on the limit's open side.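

For the compounds shown here, the results for compound 2 and compound 4 are both limits rather than numbers, so no step between them can be read. The compounds shown leave open whether methyl in place of hydrogen on an oxygen on an aromatic ring has any effect on these cells.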